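This account rests on a few compounds, and the source may have more. Where it says the series, first, only, none or still open, it means among the compounds named here.

Measured so far:
- compound 1 `Cc1nc(CN2CCN(c3cccc4[nH]c(-c5ccc(C(C)(C)C)cc5)nc34)CC2)c[nH]1`: 28 nM
- compound 2 `CCc1nc(C)c(CN2CCN(c3cccc4[nH]c(-c5ccc(C(C)(C)C)cc5)nc34)CC2)o1`: 320 nM
- compound 3 `CCc1cc(CN2CCN(c3cccc4[nH]c(-c5ccc(C(C)(C)C)cc5)nc34)CC2)n(C)n1`: 250 nM

All three share the same core and differ only in the small aromatic ring carried on the saturated chain carbon bound to an amine nitrogen in a ring. In an assay on isolated protein for displacement of a labelled ligand from Gonadotropin-releasing hormone receptor (Rattus norvegicus) (on this read-out lower numbers stand for stronger inhibition and higher numbers for weaker inhibition), compound 3 stands second highest of the three numbers; its nearest neighbour is compound 2, and the gap a 1.3-fold lower number from compound 2 to compound 3 (0.11 log units; within the scatter) is within the scatter, so those two cannot be ordered. The furthest is compound 1, and the step of an 8.9-fold higher number from compound 1 to compound 3 (0.95 log units; beyond the scatter) is beyond the scatter.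

Compound 4 `Cc1nc(CN2CCN(c3cccc4[nH]c(-c5ccc(C(C)(C)C)cc5)nc34)CC2)cn1C` has not yet been measured. Its change from compound 3 is 1,2-dimethyl-1H-imidazol-4-yl in place of 3-ethyl-1-methyl-1H-pyrazol-5-yl on a saturated chain carbon bound to an amine nitrogen in a ring. The entering ring is closely related to the 2-methyl-1H-imidazol-4-yl of compound 1, differing by a methyl on a ring nitrogen. For the measured compounds named here, the steps that bear on this are an 8.9-fold higher number from compound 1 to compound 3 (0.95 log units; beyond the scatter) and an 11-fold higher number from compound 1 to compound 2 (1.06 log units; beyond the scatter), both large moves away from the imidazole of compound 1; a return toward an imidazole is therefore expected to move the number back down in this assay. Because compound 1 gives 28 nM with a ring that is not identical to the entering one, only part of that step is expected to be recovered, and the estimated change is a 4.2-fold lower number from compound 3 to compound 4 (0.62 log units; beyond the scatter). Compound 4 is accordingly expected to give about 60 nM in this assay, with a plausible range from 20 nM to 250 nM.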

Compound 4, half-maximal inhibitory concentration: 34 nM
For compound 4 the middle estimate is 1.8-fold (0.25 log units) above the measured one, within the range that was stated.
By their numbers in this assay, from the lowest: compounds 1 and 4 (each within the scatter of the next); then compounds 3 and 2 (each within the scatter of the next).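

The methyl on the aromatic nitrogen gives a 1.2-fold higher number from compound 1 to compound 4 (0.08 log units; within the scatter) in this assay and so leaves the number unchanged within the scatter, which shows that the hydrogen on that nitrogen is not required at this position. The two imidazole rings stand apart from the other two rings in this set: a 7.4-fold lower number from compound 3 to compound 4 (0.87 log units; beyond the scatter) and a 9.4-fold lower number from compound 2 to compound 4 (0.97 log units; beyond the scatter) are both beyond the scatter, and since neither 1,2-dimethyl-1H-imidazol-4-yl nor 3-ethyl-1-methyl-1H-pyrazol-5-yl has a hydrogen-bond donor, the absence of a donor cannot explain the gap between them. Nothing measured here explains why these rings differ.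

The 3-ethyl-1-methyl-1H-pyrazol-5-yl ring differs from the imidazole in both its ethyl and its ring arrangement, and these compounds do not separate the two. Going by these compounds, how an imidazole with an ethyl in place of its carbon-bound methyl, or a triazole ring, would behave also remains open.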